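Swapping the carbonyl aryl group of compound 1

The source may report more compounds than this note shows. Statements on the series, on what has been measured and on what is new or still open speak of the compounds shown alone.

Among the measured compounds shown here, in a functional assay on DU-145 cells (Homo sapiens) for inhibition, read by trypan blue exclusion, with a stated time of 96 h (on this read-out lower numbers stand for stronger inhibition of growth and higher numbers for weaker inhibition of growth), compound 1 `O=C(/C(=C\c1ccc([N+](=O)[O-])c(O)c1)SCc1ccc(Br)cc1)c1ccc([N+](=O)[O-])cc1` gives 1000 nM and holds the lower of the two numbers so far, while compound 2 `O=C(/C(=C\c1ccc(O)c([N+](=O)[O-])c1)SCc1ccc(Br)cc1)c1ccc([N+](=O)[O-])cc1` gives 10000 nM in the same test. For the measured compounds named here, compound 3 `O=C(/C(=C\c1ccc([N+](=O)[O-])c(O)c1)SCc1ccc(Br)cc1)c1cc(Cl)ccc1O` keeps the rest of compound 1 and brings 5-chloro-2-hydroxyphenyl in place of 4-nitrophenyl on a carbonyl carbon as its one change. Going by the values given here, the only measured step is a 10-fold higher number from compound 1 to compound 2 (1.00 log units; beyond the scatter) and it concerns a different group, so it bears on this swap only indirectly. It does show that one change to this structure can move the number beyond the scatter. Among the compounds with values here, no measured step touches the carbonyl side, so a modest rise is expected, and the expected step is a 2.5-fold higher number from compound 1 to compound 3 (0.40 log units; beyond the scatter) in this assay as a rough guess. The estimate for compound 3 is 2500 nM (expected range 600 nM to 10000 nM).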

Compound 3, concentration for 50% growth inhibition: 10000 nM
Estimate against measurement, compound 3: 4.0-fold (0.60 log units) below; low and high end bracket the measured number.
By their numbers in this assay, from the lowest: compound 1; then compounds 2 and 3 (each within the scatter of the next).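

In this assay, the swap of 4-nitrophenyl for 5-chloro-2-hydroxyphenyl on a carbonyl carbon gives a 10-fold higher number from compound 1 to compound 3 (1.00 log units; beyond the scatter), so this place, which the earlier pair left untouched, also moves the number beyond the scatter. Of the two groups seen here on the carbonyl carbon, 4-nitrophenyl goes with the lower number and thus the stronger inhibition of growth. No measurement is at hand that would account for this step.

The entering group differs from the leaving one in more than one feature, so the compounds shown cannot separate the part played by the chlorine from that of the hydroxy group, or from the loss of the nitro group. On these data alone, how an unsubstituted phenyl, a 4-aminophenyl or a 4-carboxyphenyl would behave on this carbonyl carbon remains open.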